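The compounds below may be only part of what the source reports. "The series", "measured", "known", "first", "only" and "open" are said of these compounds alone.

Compound 1 `CCOC(=O)c1c(-c2cccs2)[nH]c2cc(OC)ccc2c1=O`. In a physicochemical assay for solubility, in phosphate buffer, at pH 7.4 (a higher number here means a more soluble compound, a lower number a less soluble compound), compound 1 gives > 100000 nM, which is a limit of the assay rather than a number.
Compound 2 `CCOC(=O)c1c(-c2cccc([N+](=O)[O-])c2)[nH]c2cccc(OC)c2c1=O`. In this assay compound 2 gives 49000 nM.
Compound 3 `CCOC(=O)c1c(-c2ccc(Cl)cc2)[nH]c2cccc(OC)c2c1=O`. In this assay compound 3 gives > 100000 nM, again a limit of the assay.

Compound 1 therefore stands at the upper edge of what this assay can report, and it is not alone there: the limit of > 100000 nM in this assay, at which 2 of the 3 values shown sit. Only compound 2 returned an actual number.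

The next compound, compound 4 `CCOC(=O)c1c(-c2cccc(Cl)c2)[nH]c2cc(OC)ccc2c1=O`, differs from compound 1 in one place: 3-chlorophenyl in place of thiophen-2-yl on an aromatic carbon. For the measured compounds named here, no measured pair makes exactly this exchange. The closest comparison is an at least 2.0-fold higher number from compound 2 to compound 3 (0.30 log units; that floor lies within the scatter), where a 4-chlorophenyl group replaced a 3-nitrophenyl group. Compound 3, the end point of that step, itself sits at the limit. Going by the values given here, since compound 1 already sits at the limit and the only measured step toward a chlorophenyl group did not fall away from it, no change beyond the scatter is expected for a number no higher from compound 1 to compound 4 (the limit leaves the size open), and compound 4 is expected to come back as a limit once more. The estimate for compound 4 is 100000 nM, with a range from 40000 nM to 250000 nM.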

Compound 4, solubility: 58000 nM
Compound 4: the middle estimate sits 1.7-fold (0.24 log units) above what was measured; low and high end bracket the measured number.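

Replacing thiophen-2-yl with 3-chlorophenyl on this aromatic carbon gives, in this assay, an at least 1.7-fold lower number from compound 1 to compound 4 (0.23 log units; that floor lies within the scatter). With 3-chlorophenyl, the core of compound 1 now returns an actual number rather than a limit of the assay, but the floor of this step does not by itself establish a real drop. How far apart the two compounds truly stand remains hidden at the top of the scale: the limit of > 100000 nM in this assay, at which 2 of the 4 values shown sit.

The compounds shown leave open whether the chlorine or the six-membered ring counts here, a question that a plain phenyl group at this position would help to separate. They also leave open what an amine or a carboxylic acid on the entering ring, or a longer chain in place of the ethoxycarbonyl group, would do in this assay.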